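This account rests on a few compounds, and the source may have more. Where it says the series, first, only, none or still open, it means among the compounds named here.

Among the compounds with values here, in a functional assay on A549 cells (Homo sapiens) for inhibition, read by CCK-8 assay, with a stated time of 48 h (on this read-out lower numbers stand for stronger inhibition and higher numbers for weaker inhibition), compound 1 `COc1cc(-c2ccnc3cc(-c4ccc(C)cc4)nn23)cc(OC)c1OC` gives 3 nM, the lowest number of the three measured so far. Compound 2 `COc1cc(-c2ccnc3cc(-c4ccc(C)c(C)c4)nn23)cc(OC)c1OC` gives 272 nM, and compound 3 `COc1cc(-c2ccnc3cc(-c4cccc(C)c4)nn23)cc(OC)c1OC` gives 5730 nM. Compound 4 `CCOC(=O)c1ccc(-c2cc3nccc(-c4cc(OC)c(OC)c(OC)c4)n3n2)cc1` is still unmeasured; it carries ethoxycarbonyl in place of methyl on an aromatic carbon, para to a large group (ethoxycarbonyl in place of methyl on an aromatic carbon). Within the data shown here, two measured steps bear on this change. Methyl in place of hydrogen gave a 91-fold higher number from compound 1 to compound 2 (1.96 log units; beyond the scatter), and 3-methylphenyl in place of 4-methylphenyl gave a 1900-fold higher number from compound 1 to compound 3 (3.28 log units; beyond the scatter). Both are large and both go upward, although neither involves ethoxycarbonyl. A large rise, toward weaker inhibition, is therefore expected in this assay, with an estimated step of a 100-fold higher number from compound 1 to compound 4 (2.00 log units; beyond the scatter). For compound 4 the estimated value is 300 nM, within an expected range of 30 nM to 3000 nM.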

Compound 4, half-maximal inhibitory concentration: > 10000 nM
Compound 4: a limit, no number (the forecaster's own chance of this, stated with the estimate: 5%); at least 33-fold (1.52 log units) between middle value and limit.
By their numbers in this assay, from the lowest: compound 1; then compound 2; then compound 3. At a limit, above all of these: compound 4.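

Replacing methyl with ethoxycarbonyl on this aromatic carbon, para to a large group, gives an at least 3300-fold higher number from compound 1 to compound 4 (3.52 log units; beyond the scatter). The earlier compounds shown here varied only methyl, in its number and its place, whereas this change replaces the group itself and shows that the low number of compound 1 does not survive it. Compound 4 stands at a limit of the assay and not at a number: the limit of > 10000 nM in this assay, at which 1 of the 4 values shown sits.

Going by these compounds, how far compound 4 lies beyond that limit remains open. So does whether an amine, a carboxylic acid or a methoxy group at this place would keep a number near that of compound 1.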